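Notes: vinyl step from compound 2 to compound 4

This account rests on a few compounds, and the source may have more. Where it says the series, first, only, none or still open, it means among the compounds named here.

Measured in an ADME assay on L1210/0 cells (Mus musculus) for cytotoxicity, with a stated time of 48 h (a higher number here means a weaker inhibitor, a lower number a stronger inhibitor), so far:
- compound 1 `Nc1nc(Cl)c2nnn(C[C@H]3CC[C@@H](CO)C3)c2n1` gives 170000 nM
- compound 2 `O=c1[nH]c(=O)n([C@H]2C[C@H](O)[C@@H](CO)O2)cc1/C=N/O` gives 15500 nM
- compound 3 `COC1=C(OCc2ccc([N+](=O)[O-])cc2)C(=O)O/C1=C\Cn1cnc2c(Cl)ncnc21` gives 13600 nM

Compound 2 (15500 nM) sits within the scatter of compound 3 (13600 nM), while compound 1 (170000 nM) has a number beyond the scatter above that of compound 2. Compound 4 `C=Cc1cn([C@H]2C[C@H](O)[C@@H](CO)O2)c(=O)[nH]c1=O` differs from compound 2 on an aromatic carbon a group of 2 heavy atoms (2 carbon; no ring) in place of a group of 3 heavy atoms (1 carbon, 1 nitrogen, 1 oxygen; no ring), on an aromatic carbon with vinyl in place of a group of 3 heavy atoms (1 carbon, 1 nitrogen, 1 oxygen; no ring). Within the data shown here, no measured pair shows this kind of change, so the size is poorly fixed. The expected step is a 2.6-fold lower number from compound 2 to compound 4 (0.41 log units; beyond the scatter) in this assay and would be modest, toward a lower number. For compound 4 the estimate is 6000 nM (range 800 nM to 40000 nM) for now.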

Compound 4, half-maximal inhibitory concentration: 14200 nM
Compound 4: middle estimate off by 2.4-fold (0.37 log units), on the low side; the measured number falls inside the stated range.
By their numbers in this assay, from the lowest: compounds 3, 4 and 2 (each within the scatter of the next); then compound 1.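

In this assay, vinyl in place of the group of 3 heavy atoms on the aromatic carbon gives a 1.1-fold lower number from compound 2 to compound 4 (0.04 log units; within the scatter), the first step read at this position. In this pair, the hydrogen-bond donor and acceptors of the leaving group can be lost without a change beyond the scatter. No supporting measurement is available to explain this result.

A single step cannot show how far this position stays insensitive. An amine, a carboxylic acid or a longer chain on the same aromatic carbon remains an open case.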